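This account rests on a few compounds, and the source may have more. Where it says the series, first, only, none or still open, it means among the compounds named here.

Measured so far in an ADME assay on the whole organism (strain Balb) for pharmacokinetics, with Mus musculus as the target, read by LC-MS, at a dose of 10 mg/kg by the intravenous route; on this read-out higher numbers stand for wider distribution into tissues and lower numbers for narrower distribution:
- compound 1 `CCc1ccc(Cl)cc1-n1cc(-c2ncnn3cccc23)cc1C(N)=O` gives 5.8 L/kg
- compound 2 `CCc1ccc(Cl)cc1-n1cc(-c2cc(N)ncn2)cc1C(N)=O` gives 0.6 L/kg
- compound 3 `Cc1ccc(Cl)cc1-c1cn(-c2ncnc3[nH]ccc23)cc1C(N)=O` has no number ("not determined" (no result reported))

Compound 2 holds the lower of the two numbers available. Its nearest neighbour is compound 1, and the gap between compound 2 at 0.6 L/kg and compound 1 at 5.8 L/kg lies beyond the scatter. Compound 3 offers no number for comparison, so the range rests on these two values alone.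

The next compound is compound 4 `CCc1ccc(Cl)cc1-n1cc(-c2cc(NC)ncn2)cc1C(N)=O`, which differs from compound 2 in one place: methyl in place of hydrogen on a nitrogen on an aromatic ring. This is methyl in place of hydrogen on a nitrogen on an aromatic ring, the change from amino to methylamino. Among the compounds with values here, no pair of measured compounds shows this change or any other single-place step, so the series gives no direct precedent. The expectation is anchored on compound 2 at 0.6 L/kg and is kept wide. In this assay the expected move is a 1.5-fold higher number from compound 2 to compound 4 (0.18 log units; within the scatter), a small upward lean that is not expected to go beyond the scatter. For compound 4 the estimated value is 0.9 L/kg, with an expected range from 0.4 L/kg to 2 L/kg.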

Compound 4, volume of distribution at steady state: 1.4 L/kg
Compound 4: middle estimate off by 1.6-fold (0.19 log units), on the low side; the range from low to high includes it.
By their numbers in this assay, from the lowest: compound 2; then compound 4; then compound 1.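

In this assay, within the data shown here, the nitrogen of the 6-aminopyrimidin-4-yl group tolerates replacement of a hydrogen by methyl, and the change to 6-(methylamino)pyrimidin-4-yl gives a 2.3-fold higher number from compound 2 to compound 4 (0.37 log units; beyond the scatter) in the only single-place step the series offers so far. This gives the series its first direct reading at this position: one added carbon, in a group with no ring, no net charge and no hydrogen-bond donors or acceptors of its own, is enough to carry the read-out past the usual scatter, though the step remains modest. No measurement in hand bears on why the number moves in this direction.

A single step cannot show whether the trend continues with a longer chain such as ethyl, with a second methyl as in dimethylamino, or with a ring such as cyclopropyl on the same nitrogen. From the compounds shown here alone, it also remains open whether methyl on an amino group would give a step of similar size and direction on another aromatic ring attached to the shared core.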